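Methylation of the amide nitrogen in compound 2

This account rests on a few compounds, and the source may have more. Where it says the series, first, only, none or still open, it means among the compounds named here.

Measured compounds:
compound 1 `Cc1cc(NNC(=O)Nc2cc(Cl)nc(Cl)c2)nc(-c2cnn(C)c2)c1`: > 2100 nM (a limit)
compound 2 `Cc1cc(NNC(=O)Nc2cc(Cl)nc(Cl)c2)nc(C(=O)NC2CC2)c1`: 4500 nM

Compound 1 `Cc1cc(NNC(=O)Nc2cc(Cl)nc(Cl)c2)nc(-c2cnn(C)c2)c1` gives > 2100 nM in a functional assay on CHO cells for antagonist activity at sphingosine 1-phosphate receptor 2 (Homo sapiens), read by fluorescence and calcium flux, with a stated time of 3 min; a higher number here means a weaker inhibitor, a lower number a stronger inhibitor; this is a limit of the assay and not a number. Compound 2 `Cc1cc(NNC(=O)Nc2cc(Cl)nc(Cl)c2)nc(C(=O)NC2CC2)c1` gives 4500 nM in this assay. Among the two values shown, compound 2 holds the only number; the other value is a limit. The step that the limit leaves unreadable from compound 1 to compound 2, cyclopropylcarbamoyl in place of 1-methyl-1H-pyrazol-4-yl on an aromatic carbon, cannot be read in size because of the limit of > 2100 nM in this assay, at which 1 of the 2 values shown sits.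

Compound 3 `Cc1cc(NNC(=O)Nc2cc(Cl)nc(Cl)c2)nc(C(=O)N(C)C2CC2)c1` differs from compound 2 by methyl in place of hydrogen on an amide-type nitrogen whose other neighbours are a carbonyl carbon and a saturated ring carbon, so cyclopropylcarbamoyl becomes cyclopropyl(methyl)carbamoyl. Going by the values given here, no measured step touches this nitrogen; the single step from compound 1 to compound 2 alters another position and is unreadable. Nothing shown therefore supports a change beyond the usual scatter in this assay, in either direction. Compound 3 is expected near 4500 nM, in the range 1500 nM to 14000 nM. The expected step is no change at the digits printed from compound 2 to compound 3 (within the scatter), within scatter.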

Compound 3, half-maximal inhibitory concentration: > 20000 nM
Compound 3: no number, only a limit; the forecaster's own chance of this, stated with the estimate: 25%; at least 4.4-fold (0.64 log units) between middle value and limit.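

Methyl in place of the amide hydrogen on the nitrogen of the cyclopropylcarbamoyl group is the first change at this position that can be read, and in this assay it gives an at least 4.4-fold higher number from compound 2 to compound 3 (0.64 log units; beyond the scatter). Compound 3 gives > 20000 nM, which is a limit of the assay and not a number. For this one pair, then, the position does not tolerate the change from cyclopropylcarbamoyl to cyclopropyl(methyl)carbamoyl without a loss of inhibition beyond the scatter, so the amide hydrogen cannot be treated as freely replaceable, although a single pair gives no reason for the loss and sets no rule for other groups on this nitrogen.

From the compounds shown here alone, the steps from compound 1, which carries 1-methyl-1H-pyrazol-4-yl, to either carbamoyl compound cannot be read, so that group and the two amides remain unranked: the limit of > 2100 nM in this assay, at which 1 of the 3 values shown sits. Still open are whether an ethyl or a 2-hydroxyethyl group on this nitrogen behaves as methyl does, and whether a cyclobutyl group in place of the cyclopropyl, with the amide hydrogen kept, holds or shifts the value of compound 2 of 4500 nM.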